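Three Compounds at the Cytotoxicity Limit, a Fourth Expected

The compounds below may be only part of what the source reports. "The series", "measured", "known", "first", "only" and "open" are said of these compounds alone.

Measured in an ADME assay on HEK293 cells (Homo sapiens) for cytotoxicity, read by luminescence, with a stated time of 72 h; on this read-out higher numbers stand for an effect only at larger amounts of compound and lower numbers for an effect already at smaller amounts:
Compound 1 `CCOC(=O)c1c(-c2cccc(OC(F)(F)F)c2)[nH]c2cc(OC)ccc2c1=O` gives > 22000 nM.
Compound 2 `CCOC(=O)c1c(-c2cccc(Cl)c2)[nH]c2cc(OC)ccc2c1=O` gives > 22000 nM.
Compound 3 `CCOC(=O)c1c(-c2cccc(OC(F)(F)F)c2)[nH]c2cc(C(F)(F)F)ccc2c1=O` gives > 22000 nM.

Each of these three values is a limit of this assay and not a number. Compound 1 and compound 2 differ by chloro in place of trifluoromethoxy on an aromatic carbon, and the step that the two limits leave unreadable from compound 1 to compound 2 cannot be read as a size. Compound 1 and compound 3 differ in their cores by trifluoromethyl in place of methoxy on an aromatic carbon, and the step that the two limits leave unreadable from compound 1 to compound 3 is likewise unreadable. What the data give is the limit of > 22000 nM in this assay, at which 3 of the 3 values shown sit.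

Compound 4 `CCOC(=O)c1c(-c2cccc(Cl)c2)[nH]c2cc(C(F)(F)F)ccc2c1=O` is not yet measured. It differs from compound 3 by chloro in place of trifluoromethoxy on an aromatic carbon, the same change as that from compound 1 to compound 2, since the two place descriptions agree word for word. Because the step that the two limits leave unreadable from compound 1 to compound 2 stayed at the limit, the expected step that the limit leaves unreadable from compound 3 to compound 4 is also expected to leave the value at or beyond the limit. For compound 4 in this assay the estimate is 30000 nM, expected to fall between 15000 nM and 100000 nM.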

Compound 4, half-maximal effective concentration: > 22000 nM
Compound 4 was reported as a limit; the forecaster's own chance of this, stated with the estimate: 80%; the middle value lies beyond the limit too.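

Compound 4 is reported only as a limit of this assay and not as a number, so neither the step from compound 3 to compound 4 nor the step from compound 2 to compound 4 can be read as a size. All four compounds stand at the same point: the limit of > 22000 nM in this assay, at which 4 of the 4 values shown sit.

As far as these compounds go, what stays open is whether any of the four compounds harms these cells at some larger amount, and whether either change of group would shift that amount.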